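Ethoxy to isopropoxy on two related cores

The compounds below may be only part of what the source reports. "The series", "measured", "known", "first", "only" and "open" are said of these compounds alone.

Compound 1 `CCOc1ccccc1N1CCN(CCCCCCCn2ncc(Cl)c(N3CCN(C(=O)c4ccco4)CC3)c2=O)CC1` and compound 2 `CC(C)Oc1ccccc1N1CCN(CCCCCCCn2ncc(Cl)c(N3CCN(C(=O)c4ccco4)CC3)c2=O)CC1` share one core; compound 3 `CCOc1ccccc1N1CCN(CCCCCCCn2ncc(N3CCN(CC4COc5ccccc5O4)CC3)c(Cl)c2=O)CC1` and compound 4 `CC(C)Oc1ccccc1N1CCN(CCCCCCCn2ncc(N3CCN(CC4COc5ccccc5O4)CC3)c(Cl)c2=O)CC1` share another. How the two cores differ is not broken down here. In an assay on cell membranes for binding affinity to Adrenergic receptor alpha-1 (Rattus norvegicus), read by radioligand binding (a lower number here means a stronger inhibitor, a higher number a weaker inhibitor), compound 1 gives 0.23 nM, and compound 2 gives 0.08 nM. The change between them is methyl in place of hydrogen on a saturated chain carbon bound to an oxygen on an aromatic ring and a saturated chain carbon and it made a step of a 2.9-fold lower number from compound 1 to compound 2 (0.46 log units; beyond the scatter). On the second core, compound 3 gives 0.42 nM in this assay; against compound 1 the two values lie within the scatter, while against compound 2 the gap is beyond it. Compound 4 carries the same change on the second core: methyl in place of hydrogen on a saturated chain carbon bound to an oxygen on an aromatic ring and a saturated chain carbon. The place of the change reads the same in both pairs. Going by the values given here, the expectation for compound 4 rests on compound 1 and compound 2, because the step of a 2.9-fold lower number from compound 1 to compound 2 (0.46 log units; beyond the scatter) is the only measured instance of this change; with one pair behind it, a repeat could land anywhere from within the scatter to the size seen there, so the expected step is set a little below the measured one. The expected step is a 2.5-fold lower number from compound 3 to compound 4 (0.39 log units; beyond the scatter). Compound 4 is therefore estimated at 0.17 nM in this assay, with the likely range running from 0.08 nM to 0.4 nM.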

Compound 4, inhibition constant: 0.31 nM
The estimate for compound 4 lay 1.8-fold (0.26 log units) below the measured number; low and high end bracket the measured number.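

In this assay, ethoxy to isopropoxy on the second core gives a 1.4-fold lower number from compound 3 to compound 4 (0.13 log units; within the scatter), so on that core the change has no effect that can be told apart from repeat measurement. Set beside the first core, the two steps do not differ by more than such measurements allow, and the data give no sign that the core alters what this change does: the same change on two cores in this assay, a 2.9-fold lower number (0.46 log units; beyond the scatter) from compound 1 to compound 2 and a 1.4-fold lower number (0.13 log units; within the scatter) from compound 3 to compound 4, 2.1-fold (0.33 log units) apart, within the scatter of two such steps This does not show that the change carries over at a fixed size, since only two pairs stand behind it, one step beyond the scatter and one within it, and the true step could be the same modest gain on both cores or could be smaller on the second core with the gap hidden by the scatter.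

The compounds shown leave open whether the trend from ethoxy to isopropoxy extends down to methoxy or up to tert-butoxy or cyclopropylmethoxy in the same place on either core. They also leave open whether a third core would side with the larger step or the smaller one, and how the change reads on any receptor other than the one in this assay.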